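4-Ethylpiperazin-1-yl to isopropylamino on the shared core

This account rests on a few compounds, and the source may have more. Where it says the series, first, only, none or still open, it means among the compounds named here.

In a functional assay on HT-29 cells (Homo sapiens) for inhibition, read by MTT assay, with a stated time of 72 h (a higher number here means a weaker inhibitor, a lower number a stronger inhibitor), compound 3 (`CCN1CCN(Cc2c(OC)cc(Oc3cccc(Nc4ccccc4)c3)cc2OC)CC1`) stands at > 20000 nM as a limit and not a number. Compound 4 (`COc1cc(Oc2cccc(Nc3ccccc3)c2)cc(OC)c1CNC(C)C`) keeps the shared core and carries isopropylamino in place of 4-ethylpiperazin-1-yl on a saturated chain carbon bound to an aromatic carbon.

The closest evidence comes from two open-chain amino groups at that place. Compound 1 (`COc1cc(Oc2cccc(Nc3ccccc3)c2)cc(OC)c1CNCCNC(C)=O`) gives 3960 nM in this assay as a measured number. Compound 2 (`COc1cc(Oc2cccc(Nc3ccccc3)c2)cc(OC)c1CNCc1ccc(C)cc1`) gives 3880 nM in the same test. Exchanging one of these groups for the other gave a 1.0-fold lower number from compound 1 to compound 2 (0.01 log units; within the scatter) as the step. Moving to 4-ethylpiperazin-1-yl gave an at least 5.0-fold higher number from compound 1 to compound 3 (0.70 log units; beyond the scatter) and an at least 5.1-fold higher number from compound 2 to compound 3 (0.71 log units; beyond the scatter) as the two steps. With only these compounds to go on, isopropylamino is expected to fall with the two open-chain amino groups. The expected step is an at least 4.4-fold lower number from compound 3 to compound 4 (0.64 log units; beyond the scatter) towards a stronger inhibitor. For compound 4 the estimated value is 4500 nM with 1800 nM to 12000 nM as the expected range.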

Compound 4, half-maximal inhibitory concentration: > 20000 nM
Compound 4: no number, only a limit; the forecaster's own chance of this, stated with the estimate: 10%; middle value at least 4.4-fold (0.64 log units) from the limit.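

In this assay compound 4 stands at > 20000 nM, a limit and not a number. Keeping an open-chain amine and changing only the group on its nitrogen gives an at least 5.1-fold higher number from compound 2 to compound 4 (0.71 log units; beyond the scatter) and an at least 5.0-fold higher number from compound 1 to compound 4 (0.70 log units; beyond the scatter), so among these compounds the drop in activity at this place does not require the ring of 4-ethylpiperazin-1-yl, and an open-chain amino group alone does not secure a measured value. The step between compound 3 and compound 4 cannot be read, as both values are limits, and the two compounds share that limit: the limit of > 20000 nM in this assay, at which 2 of the 4 values shown sit.

As far as these compounds go, whether a straight butyl chain or a cyclohexylmethyl group on the amine nitrogen would fall with compound 1 and compound 2 or with compound 4 remains open. Also open, from the compounds shown here alone, is how far compound 3 and compound 4 lie from each other beyond the limit.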